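This account rests on a few compounds, and the source may have more. Where it says the series, first, only, none or still open, it means among the compounds named here.

Notes on the series. Compound 1 `Cc1ccc(-c2nc3sc(Cc4ccc(Cl)cc4)nn3c2Br)cc1` carries bromo on the shared core. Within the data shown here, in an ADME assay on CCRF-CEM cells (Homo sapiens) for cytotoxicity, with a stated time of 72 h (on this read-out lower numbers stand for stronger inhibition and higher numbers for weaker inhibition), compound 1 reaches only the limit of the assay, > 250000 nM. the limit of > 250000 nM in this assay, at which 1 of the 2 values shown sits, is the sole evidence on where compound 1 stands. Compound 2 `O=[N+]([O-])c1ccc(-c2nc3sc(Cc4ccc(Cl)cc4)nn3c2Br)cc1` differs from compound 1 by nitro in place of methyl on an aromatic carbon, and in this assay compound 2 gives 73000 nM. That step, an at least 3.4-fold lower number from compound 1 to compound 2 (0.53 log units; beyond the scatter), changes the 4-methylphenyl group and not the position altered in compound 3. Compound 3 `Cc1ccc(-c2nc3sc(Cc4ccc(Cl)cc4)nn3c2SC#N)cc1` differs from compound 1 by cyanosulfanyl in place of bromo on an aromatic carbon. Among the measured compounds shown here, no measured step covers cyanosulfanyl in place of bromo on an aromatic carbon, so the expectation rests on the limit of compound 1 alone, and a result at the limit remains likely. The step from compound 1 to compound 3 is expected to be an at least 1.3-fold lower number from compound 1 to compound 3 (0.14 log units; that floor lies within the scatter). Compound 3 is estimated at 180000 nM in this assay, within a range from 40000 nM to 400000 nM.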

Compound 3, half-maximal inhibitory concentration: 22000 nM
Compound 3: middle estimate off by 8.2-fold (0.91 log units), on the high side; the measured number lies below the stated range.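

Cyanosulfanyl in place of bromo gives an at least 11-fold lower number from compound 1 to compound 3 (1.05 log units; beyond the scatter) in this assay, so the position on the shared core also responds, and not only the 4-methylphenyl group changed in the earlier step. The new step is a floor and not a full size, since compound 1, its starting point, is a limit of the assay: the limit of > 250000 nM in this assay, at which 1 of the 3 values shown sits. With an at least 3.4-fold lower number from compound 1 to compound 2 (0.53 log units; beyond the scatter) also printed as beyond the scatter, a change at either of these two places on compound 1 lowers the number in this assay.

The compounds shown do not tell whether the sulfur or the nitrile carries the step, which a methylsulfanyl group or a nitrile alone at this position would separate. Also open, as far as these compounds go, is how cyanosulfanyl at this position behaves when nitro replaces methyl on the aromatic ring.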